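A few compounds are considered here, and "the series" means these few. Any claim that something is new, unique, unknown or untested is made for them only; others in the source may bear on it.

Cytotoxicity in this series is followed in an ADME assay on BJ cells (Homo sapiens) for cytotoxicity, read by CellTiter-Glo and resazurin assay, with a stated time of 72 h; on this read-out lower numbers stand for an effect already at smaller amounts and higher numbers for an effect only at larger amounts of compound. Compound 1, `CC(C)N(Cc1cccc(OCCCCCC(=O)O)c1)C(=O)c1ccc(-c2ccc3c(c2)OCCO3)cc1`, gives in this assay > 21900 nM, which is a limit of the measurement and not a number. Compound 2, `CCOC(=O)CCCCCOc1cccc(CN(C(=O)c2ccc(-c3cnc(OC)nc3OC)cc2)C(C)C)c1`, gives in this assay > 26000 nM, again a limit rather than a number. Among the compounds with values here, both compounds therefore stand at a limit, as the limit of > 21900 nM in this assay, at which 1 of the 2 values shown sits, and the limit of > 26000 nM in this assay, at which 1 of the 2 values shown sits, show, and no step between them can be sized; compound 2 stands at one of the two limits recorded. Compound 3, `CCOC(=O)CCCCCOc1cccc(CN(C(=O)c2ccc(-c3cc(OC)cc(OC)c3)cc2)C(C)C)c1`, has not yet been measured in this assay. It differs from compound 2 in one place: 3,5-dimethoxyphenyl in place of 2,4-dimethoxypyrimidin-5-yl on an aromatic carbon. Within the data shown here, with no measured step to judge by, the change is expected to bring no shift beyond the scatter, and a limit is the most likely outcome. The step is estimated at a step that the limit leaves unreadable from compound 2 to compound 3. Compound 3 is expected at 30000 nM, within a range of 15000 nM to 80000 nM.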

Compound 3, half-maximal effective concentration: > 26000 nM
Compound 3 was reported as a limit; the forecaster's own chance of this, stated with the estimate: 80%; the middle value is on the limit's open side.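

No step from compound 2 to compound 3 can be read, since both are reported only as the same limit: the limit of > 26000 nM in this assay, at which 2 of the 3 values shown sit.

Still open is whether 3,5-dimethoxyphenyl and 2,4-dimethoxypyrimidin-5-yl differ at all in this assay, and at what concentration any compound shown would reach its half-maximal effect.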